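This account rests on a few compounds, and the source may have more. Where it says the series, first, only, none or still open, it means among the compounds named here.

Working notes on the series. In a functional assay on HCT-116 cells (Homo sapiens) for antiproliferative activity, read by sulforhodamine B assay, with a stated time of 3 days, tested at 25 uM (a lower number here means a weaker effect, a higher number a stronger effect of the compound at the concentration tested), compound 1 `O=C(/C=C/c1ccccc1Cl)c1ccc(OCc2ccccc2)cc1` gives 54.5% and compound 2 `O=C(/C=C/c1ccccc1)c1ccc(OCc2ccccc2)cc1` gives 24.3%. Within the data shown here, the single measured step, a number 30.2 percentage points lower from compound 1 to compound 2 (beyond the scatter), is the only one-place change so far. Compound 3 `Cc1ccc(COc2ccc(C(=O)/C=C/c3ccc(Cl)cc3)cc2)cc1` gives 12.3% in this assay, the lowest of the three numbers: its gap to compound 2 and its larger gap to compound 1 both lie beyond the scatter.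

The next step leads to compound 4 `O=C(/C=C/c1ccc(Cl)cc1)c1ccc(OCc2ccccc2)cc1`. The change is hydrogen in place of methyl on an aromatic carbon, on an aromatic carbon of a six-membered aromatic ring of carbon only; one bond further out it reads 4-methylbenzyl to benzyl. Among the measured compounds shown here, no measured step bears on this change. The step from compound 1 to compound 2 concerns a chloro on the other aromatic ring and says nothing about removing a methyl. Nothing measured therefore suggests a step in this assay beyond the scatter in either direction.

Compound 4 is expected near 20%, within 5% to 42%. The step of a number 7.7 percentage points higher from compound 3 to compound 4 (within the scatter) is estimated to stay within the scatter.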

Compound 4, a percentage reported as inhibition, at one concentration (the size of the read-out at that concentration, not a potency): 0.3%
Compound 4: middle estimate off by 19.7 percentage points, on the high side, and the stated range ends above it.
By their numbers in this assay, from the lowest: compound 4; then compound 3; then compound 2; then compound 1.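

Removing the methyl lowers the number in this assay (a number 12 percentage points lower from compound 3 to compound 4 (beyond the scatter)), the first measured sign that this place on the benzyl ring affects the read-out. Among these compounds, the chloro's effect also depends on where it sits: 4-chlorophenyl stands lower than both phenyl (a number 24 percentage points lower from compound 2 to compound 4 (beyond the scatter)) and 2-chlorophenyl (a number 54.2 percentage points lower from compound 1 to compound 4 (beyond the scatter)), whereas the earlier step showed only that the 2-chloro compound stands above its unsubstituted partner. Nothing at hand explains either step.

The compounds shown leave open whether the methyl step would hold with 2-chlorophenyl in place of 4-chlorophenyl, since compound 3 is the only methyl compound here. They also leave open how a methoxy group or an amine in place of that methyl would read.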